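Pentylamide of a vinyl-dihydrofuran acid in a cell assay

The compounds below may be only part of what the source reports. "The series", "measured", "known", "first", "only" and "open" are said of these compounds alone.

Compound 1 `C=CC1=C(C(=O)NCCC)C(c2ccc(F)cc2)OC1`: > 100000 nM (a limit of the assay)
Compound 2 `C=CC1=C(C(=O)O)C(c2ccc(F)cc2)OC1`: > 100000 nM (a limit of the assay)
Compound 3 `C=CC1=C(C(=O)O)C(c2ccc(OC)cc2)OC1`: > 100000 nM (a limit of the assay)

In a functional assay on A549 cells (Homo sapiens) for cytotoxicity, read by MTT assay, with a stated time of 24 h (on this read-out higher numbers stand for weaker inhibition and lower numbers for stronger inhibition), compound 3 reaches only a limit, so where it stands among the three compounds cannot be told; all three values sit at the limit of > 100000 nM in this assay, at which 3 of the 3 values shown sit.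

Compound 4 `C=CC1=C(C(=O)NCCCCC)C(c2ccc(OC)cc2)OC1` differs from compound 3 in one place: pentylamino in place of hydroxy on a carbonyl carbon.

For the measured compounds named here, two measured steps bear on this change. The step that the two limits leave unreadable from compound 1 to compound 2 swaps an amide for the free acid on the same carbonyl carbon, but both ends are limits, so its size is not readable. The step that the two limits leave unreadable from compound 2 to compound 3 changes the aromatic substituent, again between two limits. Neither step gives a readable size in this assay, so no direction can be drawn from them.

Compound 1 carries a propylamino on this carbonyl carbon and gives only a limit, so compound 4 with a pentylamino is expected to stay at the limit as well, with a step that the limit leaves unreadable from compound 3 to compound 4 expected to lie within the scatter. The estimate for compound 4 is 200000 nM, with a range from 50000 nM to 1000000 nM.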

Compound 4, half-maximal inhibitory concentration: 36500 nM
The estimate for compound 4 lay 5.5-fold (0.74 log units) above the measured number, outside the stated range (below it).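

This position on the carbonyl carbon can change the outcome in this assay: pentylamino in place of hydroxy gives an at least 2.7-fold lower number from compound 3 to compound 4 (0.43 log units; beyond the scatter), which is a real gain in cytotoxic strength, though compound 3 supplies only a limit, so the true size may be larger. For the compounds shown here, compound 4 is the first compound here with a measured number, and it gives a fixed point for later comparison. The earlier steps cannot be read, and the other compounds remain at a limit of the assay: the limit of > 100000 nM in this assay, at which 3 of the 4 values shown sit.

A single step cannot show whether a longer chain such as octylamino on this carbonyl carbon would lower the number further. It also leaves open whether pentylamino would have a similar effect with fluoro in place of methoxy on the aromatic carbon.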